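Second methoxy on the shared core: cytotoxicity working notes

This account rests on a few compounds, and the source may have more. Where it says the series, first, only, none or still open, it means among the compounds named here.

Compound 1 `COc1cccc2cc(-c3ccccc3)c(O)nc12` and compound 2 `COc1ccc2cc(-c3ccccc3)c(O)nc2c1` share one core and differ only in where their single methoxy sits. In a functional assay on A 172 cells (Homo sapiens) for cytotoxicity, read by colorimetric assay and MTT assay (a lower number here means a stronger inhibitor, a higher number a weaker inhibitor), compound 1 gives 10000 nM. In this assay compound 2 gives 10000 nM, level with compound 1 at the digits shown; the two values lie within the usual scatter, so no order between them can be read.

Compound 3 `COc1cc(OC)c2cc(-c3ccccc3)c(O)nc2c1` carries both methoxy groups and is compound 2 with one change: methoxy in place of hydrogen on an aromatic carbon. Going by the values given here, no step between measured compounds covers this change, and the two measured values sit at the same figure, so the series gives no lead on direction. Moving a methoxy around the core left the reading unchanged, with compound 1 at 10000 nM and compound 2 at 10000 nM, which is the only evidence to go on.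

The step of no change at the digits printed from compound 2 to compound 3 (within the scatter) is therefore expected to be none beyond the scatter. For compound 3 in this assay the estimate is 10000 nM, with a range from 4000 nM to 25000 nM.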

Compound 3, half-maximal inhibitory concentration: 10000 nM
Compound 3: middle estimate and measured number agree at the digits printed, within the range that was stated.
By their numbers in this assay, from the lowest: compounds 1, 2 and 3 (each within the scatter of the next).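

In this assay, the step for methoxy in place of hydrogen on an aromatic carbon, ortho to a fused ring and meta to a methoxy group, is no change at the digits printed from compound 2 to compound 3 (within the scatter), so this added methoxy gives no readable shift at this position. Compounds 1 and 2 showed only that the single methoxy could sit in either of two places without a readable difference, whereas this step shows that the core can also carry two methoxy groups with the reading still within the scatter. Nothing available explains this flat result or bears on the role of this position.

The compounds shown leave open whether a different group on this aromatic carbon, such as an amine, a carboxylic acid or a chain longer than methoxy, would separate from compound 2 in this assay. They also leave open whether a change elsewhere, such as a chloro or amino substituent on the phenyl ring, would move the reading for this series.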